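The source may hold more compounds than are shown below. What is called first, only, known or untested is meant among the compounds shown, and "the series" means these compounds.

Series notes

- Compound 1 `CCSC[C@@](O)([C@@H](Nc1cccc2nc(C)ccc12)c1ccc(OC)c(F)c1)C(F)(F)F`: in a functional assay on THP-1 cells (Homo sapiens) (a higher number here means a larger maximal response, a lower number a smaller maximal response), compound 1 gives 82%.
- Compound 2 `CCSC[C@@](O)([C@@H](Nc1cccc2nc(C)ccc12)c1ccc(Cl)c(F)c1O)C(F)(F)F`: in this assay compound 2 gives 107%.
- Compound 3 `COc1ccc([C@H](Nc2cccc3nc(C)ccc23)[C@](O)(CSC)C(F)(F)F)c(Cl)c1F`: in this assay compound 3 gives 98%.

Compound 3 stands second highest of the three numbers in this assay. Its nearest neighbour is compound 2, whose number lies within the scatter of that of compound 3, so no order between the two can be claimed; its furthest is compound 1, which lies beyond the scatter below it. Going by the values given here, the only measured step between compounds that differ in one place, a number 25 percentage points higher from compound 1 to compound 2 (beyond the scatter), swaps the aryl group on the chain carbon bound to the nitrogen and leaves the rest of the saturated chain unchanged.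

Compound 4 `COc1ccc([C@H](Nc2cccc3nc(C)ccc23)[C@](O)(CN(C)C)C(F)(F)F)c(Cl)c1F` differs from compound 3 in one place: dimethylamino in place of methylsulfanyl on a saturated chain carbon, two bonds along the chain from an oxygen on a saturated carbon. Among the compounds with values here, no measured pair alters this part of the chain, so there is no step from which the size or direction of this change in this assay can be read. With nothing to point either way, the expected step is a number 2 percentage points lower from compound 3 to compound 4 (within the scatter), one within the scatter. Compound 4 is therefore estimated at 96% in this assay, with a range from 78% to 114%.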

Compound 4, largest response reached (Emax), in percent of the reference or control that the assay uses in the THP-1 assay: 77%
Beside the measured number, compound 4's estimate is 19 percentage points above it; the measured number lies below the stated range.
By their numbers in the THP-1 assay, from the lowest: compounds 4 and 1 (each within the scatter of the next); then compounds 3 and 2 (each within the scatter of the next).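

In the THP-1 assay, this first measured change at the position gives a number 21 percentage points lower from compound 3 to compound 4 (beyond the scatter), so the group on this saturated chain carbon, two bonds along the chain from an oxygen on a saturated carbon, bears on the maximal response, and the aryl group is not the only part of the series that does. In a physicochemical assay for lipophilicity (on this read-out lower numbers stand for lower lipophilicity and higher numbers for higher lipophilicity), compound 3 gives 4.5 and compound 4 gives 5.3, so the same swap of methylsulfanyl for dimethylamino also moves this second read-out. Lipophilicity rises as the maximal response falls, but this is a single pair and does not separate one effect from the other: the measured partition coefficient of compound 3, 4.5, and of compound 4, 5.3, a number 0.80 log units higher (beyond the scatter)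

A methylamino or morpholine group at this carbon would help show whether the step follows the nitrogen itself or the extra carbon of dimethylamino. From the compounds shown here alone, whether the step carries over to the aryl groups of compound 1 and compound 2 also stays open.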